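Notes on the step from compound 3 to compound 4

The compounds below may be only part of what the source reports. "The series", "measured", "known", "first", "only" and "open" are said of these compounds alone.

Measured so far in an ADME assay on A549 cells (Homo sapiens) for cytotoxicity, read by resazurin assay, with a stated time of 48 h; on this read-out higher numbers stand for lower toxicity in this test and lower numbers for higher toxicity in this test
compound 1 `CCCNc1ccc(NC(=O)c2cc(Cl)ccc2O)c(Cl)c1`: 22500 nM
compound 2 `CC(C)Nc1ccc(NC(=O)c2cc(Cl)ccc2O)c(Cl)c1`: 11000 nM
compound 3 `O=C(Nc1ccc(NCC2CCCC2)cc1Cl)c1cc(Cl)ccc1O`: 21500 nM

Compound 3 lies within the scatter of both compound 1 and compound 2. Compound 4 `O=C(Nc1ccc(N(CC2CC2)CC2CC2)cc1Cl)c1cc(Cl)ccc1O` differs from it as follows: bis(cyclopropylmethyl)amino in place of (cyclopentylmethyl)amino on an aromatic carbon. The bearing steps are all changes on the same nitrogen. Within the scatter are a 1.0-fold lower number from compound 1 to compound 3 (0.02 log units; within the scatter) and a 2.0-fold higher number from compound 2 to compound 3 (0.29 log units; within the scatter), while a 2.0-fold lower number from compound 1 to compound 2 (0.31 log units; beyond the scatter) is modest. For the measured compounds named here, no measured compound has two substituents on this nitrogen, so the extrapolation is loose. No step beyond the scatter is expected in this assay, with a slight lean towards a lower number. The estimated step is a 1.3-fold lower number from compound 3 to compound 4 (0.13 log units; within the scatter). For compound 4 the estimated value is 16000 nM, with an expected range of 7000 nM to 36000 nM.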

Compound 4, half-maximal cytotoxic concentration: 12800 nM
The estimate for compound 4 lay 1.3-fold (0.10 log units) above the measured number; measured number inside the range.
By their numbers in this assay, from the lowest: compounds 2, 4, 3 and 1 (each within the scatter of the next, the first and the last beyond it).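

In this assay, the first compound shown with two substituents on this nitrogen and no hydrogen-bond donor there stays within the scatter of all three compounds with one substituent: a 1.7-fold lower number from compound 3 to compound 4 (0.23 log units; within the scatter) and a 1.2-fold higher number from compound 2 to compound 4 (0.07 log units; within the scatter) and a 1.8-fold lower number from compound 1 to compound 4 (0.24 log units; within the scatter) are the steps. Across these four compounds, adding the second substituent and losing that donor therefore produce no step beyond the scatter. No measurement shown accounts for these numbers.

Open, going by these compounds, is whether a smaller tertiary group such as dimethylamino, or the unsubstituted amine, would stay within the scatter. The effect of the second substituent also remains unseparated from that of the cyclopropyl rings.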